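Swapping an aromatic side ring for an isobutyl chain

The source may report more compounds than this note shows. Statements on the series, on what has been measured and on what is new or still open speak of the compounds shown alone.

The three compounds that have been measured share one core with a carboxylic acid-bearing arm. Compound 1 `O=C(O)c1cccc(Cc2c(-c3ccccc3)nn3cc(Br)ccc23)n1` is the strongest inhibitor in a functional assay on cells for antagonist activity at prostaglandin E2 receptor EP1 subtype (Rattus norvegicus), read by fluorescence and calcium flux, with a stated time of 60 s (on this read-out lower numbers stand for stronger inhibition and higher numbers for weaker inhibition), giving 11 nM. Compound 2 `CS(=O)(=O)c1ccc2c(Cc3cccc(C(=O)O)n3)c(-c3ccccc3)nn2c1` gives 5400 nM in this assay, and compound 3 `O=C(O)c1cccc(Cc2c(-c3cccs3)nn3cc(Cl)ccc23)n1` gives 1100 nM, which places compound 3 second highest of the three numbers, closest to compound 2 and far from compound 1. For the measured compounds named here, the one single-point step recorded so far, a 490-fold higher number from compound 1 to compound 2 (2.69 log units; beyond the scatter), concerns a different position from the one that changes next and so bears on it only as a warning that this core tolerates substitution poorly. Compound 4 `CC(C)Cc1nn2cc(Cl)ccc2c1Cc1cccc(C(=O)O)n1` differs from compound 3 by isobutyl in place of thiophen-2-yl on an aromatic carbon. Going by the values given here, no measured pair shows an aromatic ring at that position replaced by a chain, so the expectation rests on the weak number of compound 3 alone. Compound 4 is expected to move by a 1.8-fold higher number from compound 3 to compound 4 (0.26 log units; within the scatter), a step that would stay near the scatter. Compound 4 is therefore estimated at 2000 nM in this assay, with a range from 500 nM to 10000 nM.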

Compound 4, half-maximal inhibitory concentration: 200 nM
Compound 4: middle estimate off by 10-fold (1.00 log units), on the high side, outside the stated range (below it).
By their numbers in this assay, from the lowest: compound 1; then compound 4; then compound 3; then compound 2.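

An aromatic ring is not required on this carbon next to the ring nitrogen: isobutyl, which has no ring and no hydrogen-bond acceptor, replaces thiophen-2-yl with a 5.5-fold lower number from compound 3 to compound 4 (0.74 log units; beyond the scatter) in this assay. For the compounds shown here, the only earlier single-place step, a 490-fold higher number from compound 1 to compound 2 (2.69 log units; beyond the scatter), was a rise at a different position, so this is the first change on the shared core seen to lower the number. Nothing at hand gives a reason for this gain.

As far as these compounds go, it remains open how a shorter chain such as ethyl, a cyclohexyl ring or a chain ending in an amine would fare at this place. From the compounds shown here alone, it is also open whether isobutyl in place of the phenyl of compound 1 would give a step of similar size.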